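The compounds below may be only part of what the source reports. "The series", "measured", "known", "first", "only" and "open" are said of these compounds alone.

Series notes. In a physicochemical assay for lipophilicity, read by spectrophotometry, using the shake flask method, measured as octanol-water partition (on this read-out higher numbers stand for higher lipophilicity and lower numbers for lower lipophilicity), compound 1 `N#Cc1ccc(C(F)F)cc1` gives 1.75 and compound 2 `FC(F)OCCc1ccccc1` gives 3.16, the higher of the two numbers, the gap to compound 1 lying beyond the scatter. Compound 3 `CSCCc1ccccc1` is the next step from compound 2, differing by methylsulfanyl in place of difluoromethoxy on a saturated chain carbon, two bonds along the chain from an aromatic carbon. Measured values for such a swap are lacking here. The expected step from compound 2 to compound 3 in this assay is a number 0.04 log units higher from compound 2 to compound 3 (within the scatter), which is none beyond the scatter. On that basis compound 3 is estimated at 3.2 in this assay, with a range from 2.7 to 3.7.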

Compound 3, partition coefficient: 2.95
Compound 3: middle estimate off by 0.25 log units, on the high side, within the range that was stated.
By their numbers in this assay, from the lowest: compound 1; then compounds 3 and 2 (each within the scatter of the next).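

At a saturated chain carbon, two bonds along the chain from an aromatic carbon, methylsulfanyl in place of difluoromethoxy gives a number 0.21 log units lower from compound 2 to compound 3 (within the scatter) in this assay. Within the data shown here, this is the first single-place step, and it shows that this change at this position leaves the read-out within the scatter. Nothing available bears on the reason for this result. As far as these compounds go, whether an amine or a carboxylic acid in the same place would stay as close to compound 2 remains open, as does the same swap on a longer chain.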